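This account rests on a few compounds, and the source may have more. Where it says the series, first, only, none or still open, it means among the compounds named here.

Measured so far:
compound 1, `COc1cc(OC)cc(C(=O)Nc2ccc(Nc3nc(C)cc(N(C)C)n3)cc2)c1`, 6310 nM;
compound 2, `COc1ccc(Nc2nc(C)cc(N(C)C)n2)cc1`, > 50100 nM;
compound 3, `Cc1cc(N(C)C)nc(Nc2ccc(C(=O)N3CCCCC3)cc2)n1`, > 50100 nM.

In an ADME assay on Vero cells (Chlorocebus sabaeus) for cytotoxicity (a lower number here means that less compound is needed, a higher number that more compound is needed for the effect), compound 3 gives only a limit, > 50100 nM. Compound 2 likewise gives only a limit, > 50100 nM. Compound 1 gives an actual number, 6310 nM. Because (the limit of > 50100 nM in this assay, at which 2 of the 3 values shown sit), the step that the two limits leave unreadable from compound 2 to compound 3 cannot be read. Compound 4, `COc1ccccc1NC(=O)c1ccc(Nc2nc(C)cc(N(C)C)n2)cc1`, differs from compound 3 by (2-methoxyphenyl)amino in place of piperidin-1-yl on a carbonyl carbon. Among the measured compounds shown here, no measured step bears directly on this change; compound 1, which also carries a carbonyl joined to an aromatic amine, is the only compound with a number. The expected step of an at least 3.3-fold lower number from compound 3 to compound 4 (0.52 log units; beyond the scatter) is therefore uncertain and may well stay within the limit. Compound 4 is estimated at 15000 nM, with a range from 4000 nM to 50100 nM.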

Compound 4, half-maximal effective concentration: 631 nM
The estimate for compound 4 lay 24-fold (1.38 log units) above the measured number; measured number below the stated range.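

In this assay, the swap on the carbonyl carbon gives an at least 79-fold lower number from compound 3 to compound 4 (1.89 log units; beyond the scatter). Compound 3 gives only a limit, > 50100 nM. Among the compounds shown here, this shows that the group on this carbonyl carbon can decide whether the compound gives a real number in this assay, which the earlier compounds could not show.

Going by these compounds, it remains open which part of (2-methoxyphenyl)amino matters: the amide hydrogen, the aromatic ring or the methoxy group. Comparing phenylamino and cyclohexylamino on the same carbonyl carbon would help separate these parts.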